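This account rests on a few compounds, and the source may have more. Where it says the series, first, only, none or still open, it means among the compounds named here.

Compound 1 `CCOC(=O)c1cnn(-c2nc(-c3ccc(OC)cc3)c(C#N)c(=O)n2C)c1N`: 68 ug/mL
Compound 2 `COc1cccc(-c2nc(NN)n(C)c(=O)c2C#N)c1OC`: 37 ug/mL
Compound 3 `Cn1c(NN)nc(-c2ccccc2O)c(C#N)c1=O`: 34 ug/mL

All three compounds were tested in a functional assay on microsomes for inhibition, with a stated time of 1 h; on this read-out higher numbers stand for weaker inhibition and lower numbers for stronger inhibition. Compound 1 stands level with compound 2 and compound 3, since the gaps among the three values lie within the usual scatter of repeated measurements.

Compound 4 `CCOC(=O)c1cnn(-c2nc(-c3cccc(O)c3O)c(C#N)c(=O)n2C)c1N` keeps the rest of compound 1 and changes one group: 2,3-dihydroxyphenyl comes in place of 4-methoxyphenyl on an aromatic carbon, ortho to a cyano group (2,3-dihydroxyphenyl in place of 4-methoxyphenyl on an aromatic carbon).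

Within the data shown here, no two measured compounds differ in one place only, so the data give no direct size for this change. Among the measured compounds shown here, compound 3 is the only measured compound with a hydroxyl group on its phenyl ring, and it gives 34 ug/mL, which is level with compound 1. This offers only weak support for a small move towards stronger inhibition, and none for a large one, so a change no larger than the scatter is expected in this assay.

The expected step is a 1.7-fold lower number from compound 1 to compound 4 (0.23 log units; within the scatter).

For compound 4 the estimate is 40 ug/mL, with an expected range of 15 ug/mL to 100 ug/mL.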

Compound 4, half-maximal inhibitory concentration: 49 ug/mL
For compound 4 the middle estimate is 1.2-fold (0.09 log units) below the measured one; the range from low to high includes it.
By their numbers in this assay, from the lowest: compounds 3, 2, 4 and 1 (each within the scatter of the next).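

In this assay, putting 2,3-dihydroxyphenyl in place of 4-methoxyphenyl on this aromatic carbon, ortho to a cyano group, gives a 1.4-fold lower number from compound 1 to compound 4 (0.14 log units; within the scatter) and so leaves the two compounds level. Among these compounds, this is the first direct reading at this position, and it shows that the position accepts a ring carrying hydrogen-bond donors, which 4-methoxyphenyl lacks, with no change in the read-out beyond the scatter. No measured evidence here speaks to why the read-out holds steady.

Open, from the compounds shown here alone, is whether a phenyl ring bearing an amine or a carboxylic acid, or a longer chain in place of the ring, would move the number beyond the scatter. This single step also cannot separate the loss of the methoxy group from the gain of the two hydroxyl groups.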